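Methyl for Fluoro: Cytotoxicity on Vero Cells Expected Unchanged

The source may hold more compounds than are shown below. What is called first, only, known or untested is meant among the compounds shown, and "the series" means these compounds.

Four compounds share one core, each carrying a furan-2-yl group and a methoxybenzyl amine. Compound 1 `COc1ccc(CNc2cc(-c3ccco3)ncn2)cc1` and compound 2 `COc1ccc(CNc2ncnc(-c3ccco3)c2[N+](=O)[O-])cc1` lack results: in an ADME assay on Vero cells (Chlorocebus sabaeus) for cytotoxicity, read by MTT assay, with a stated time of 72 h (a higher number here means a weaker inhibitor, a lower number a stronger inhibitor), compound 1 gives "not determined" (no result reported), and compound 2 gives "not determined" (no result reported). Among the measured compounds shown here, compound 3 `COc1ccc(CNc2nc(F)nc(-c3ccco3)c2NC=O)cc1` is the only one with a reading. In this assay compound 3 gives > 40 ug/mL, which is a limit of the assay rather than a number, so compound 3 sits at the limit of > 40 ug/mL in this assay, at which 1 of the 3 values shown sits. Compound 4 `COc1ccc(CNc2nc(C)nc(-c3ccco3)c2NC=O)cc1` differs from compound 3 by methyl in place of fluoro on an aromatic carbon. For the measured compounds named here, no measured step is available, so the change from compound 3 to compound 4 is expected to stay within the scatter, as a step that the limit leaves unreadable from compound 3 to compound 4. Compound 4 is estimated at 50 ug/mL, expected between 25 ug/mL and 100 ug/mL.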

Compound 4, half-maximal inhibitory concentration: > 40 ug/mL
Compound 4 was reported as a limit; the forecaster's own chance of this, stated with the estimate: 70%; the middle value does not contradict the limit.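

Compound 3 and compound 4 each carry a limit of the assay rather than a number, so no step can be read between them: the limit of > 40 ug/mL in this assay, at which 2 of the 4 values shown sit.

Left open is where either compound truly falls in this assay and whether methyl in place of fluoro on an aromatic carbon changes the reading at all.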